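Aryl-substituted morpholinyl phenylethanols at the dopamine transporter

The source may report more compounds than this note shows. Statements on the series, on what has been measured and on what is new or still open speak of the compounds shown alone.

Measured so far:
compound 1 `CCOc1ccccc1C[C@@](O)(c1ccccc1)[C@@H]1CNCCO1` — 3.8%
compound 2 `O[C@](Cc1ccccc1)(c1ccccc1)[C@@H]1CNCCO1` — 5.5%

In an assay on isolated protein for displacement of a labelled ligand from sodium-dependent dopamine transporter (Homo sapiens), tested at 1000 nM (a lower number here means less inhibition, a higher number more inhibition at the concentration tested (going by the name of the read-out)), compound 2 gives 5.5%, the higher of two numbers, with compound 1 nearest at 3.8%, within the scatter. Among the compounds with values here, the only measured step, a number 1.7 percentage points higher from compound 1 to compound 2 (within the scatter), is within the scatter. Compound 3 `O[C@](Cc1ccccc1-c1ccccc1)(c1ccccc1)[C@@H]1CNCCO1` carries phenyl in place of hydrogen on an aromatic carbon. Within the data shown here, no measured step bears on this change; the one known substituent change on that aromatic carbon left the read-out unchanged. The step of a number 1.5 percentage points higher from compound 2 to compound 3 (within the scatter) is therefore expected to stay within the scatter. Compound 3 is estimated at 7%, between 0% and 20%.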

Compound 3, a percentage reported as inhibition, at one concentration (the size of the read-out at that concentration, not a potency): 2.9%
Beside the measured number, compound 3's estimate is 4.1 percentage points above it, and the stated range covers the measured number.
By their numbers in this assay, from the lowest: compounds 3, 1 and 2 (each within the scatter of the next).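

Phenyl in place of hydrogen on the aromatic carbon, ortho to a large group, reads as a number 2.6 percentage points lower from compound 2 to compound 3 (within the scatter) in this assay, and phenyl in place of ethoxy reads as a number 0.9 percentage points lower from compound 1 to compound 3 (within the scatter) at the same carbon. Hydrogen, ethoxy and phenyl at this carbon therefore cannot be told apart in this read-out, even with a whole aromatic ring entering there. No evidence on the cause accompanies this result.

Going by these compounds, whether an amine or a carboxylic acid on this carbon would give a step beyond the scatter remains open.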